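Adding a prenyl group to compound 2

This account rests on a few compounds, and the source may have more. Where it says the series, first, only, none or still open, it means among the compounds named here.

Compound 1 `CC(C)=CCCC(C)=CCNCCCN1CCCC1=O` in a toxicity assay on CHO cells (Cricetulus griseus) for cytotoxicity, read by WST assay, with a stated time of 24 h (on this read-out lower numbers stand for stronger inhibition and higher numbers for weaker inhibition), gives > 150000 nM as a limit
Compound 2 `CC(C)=CCCC(C)=CCNCCCN(C)CCCN` in this assay gives > 150000 nM as a limit

Compound 2 sits at a limit of the assay and so has no exact number on the scale. Both measured compounds stand in this position, as the limit of > 150000 nM in this assay, at which 2 of the 2 values shown sit, shows for this small set. The change to compound 3 `CC(C)=CCC/C(C)=C\CCC(C)=CCNCCCN(C)CCCN` is 3-methylbut-2-en-1-yl in place of hydrogen on a saturated chain carbon bound to a double-bonded chain carbon and nothing else. Among the measured compounds shown here, the one measured step, a step that the two limits leave unreadable from compound 1 to compound 2, lies at another place on the molecule and has no readable size, so it offers no size to carry over. Starting from compound 2 at > 150000 nM as a limit, any readable move is expected toward stronger inhibition, although compound 3 may also stay at a limit. The data do not fix the size of this move, so the following figure is only a cautious judgement. The expected change is an estimated at least 1.6-fold lower number from compound 2 to compound 3 (0.22 log units; that floor lies within the scatter) on this reading. For compound 3 the estimated value is 90000 nM with an expected range from 30000 nM to 200000 nM in this measurement.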

Compound 3, half-maximal inhibitory concentration: 10500 nM
Beside the measured number, compound 3's estimate is 8.6-fold (0.93 log units) above it, and the stated range ends above it.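

In this assay, among the compounds shown here, 3-methylbut-2-en-1-yl in place of hydrogen on a saturated chain carbon bound to a double-bonded chain carbon gives an at least 14-fold lower number from compound 2 to compound 3 (1.15 log units; beyond the scatter) and so makes this the first change in the set with a readable size. For the compounds shown here, the earlier step from compound 1 to compound 2 cannot be read, which leaves compound 3 as the only compound here with an exact number on the scale. The true step could be larger than this printed floor, because compound 2 supplies only a limit and not an exact starting number: the limit of > 150000 nM in this assay, at which 2 of the 3 values shown sit.

The compounds shown leave open whether the drop in the number needs this particular group, or whether a plain methyl or a saturated pentyl chain on the same carbon would move it in the same way. They also leave open whether the longer chain of compound 3 would lower the number to a similar degree with the 2-oxopyrrolidin-1-yl end of compound 1 in place of the (3-aminopropyl)(methyl)amino end.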